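A few compounds are considered here, and "the series" means these few. Any claim that something is new, unique, unknown or untested is made for them only; others in the source may bear on it.

Among the measured compounds shown here, in a physicochemical assay for lipophilicity, using the shake flask method (a lower number here means a more polar compound, a higher number a more lipophilic compound), compound 2 `C#CCO/N=C/c1c(N)ncnc1Oc1ccc(NC(=O)C2(C(=O)Nc3ccc(F)cc3)CC2)cc1F` gives 3.34, the higher of the two numbers so far, and compound 1 `N/N=C/c1c(N)ncnc1Oc1ccc(NC(=O)C2(C(=O)Nc3ccc(F)cc3)CC2)cc1F` gives 2.25. Compound 3 `CC(O)CO/N=C/c1c(N)ncnc1Oc1ccc(NC(=O)C2(C(=O)Nc3ccc(F)cc3)CC2)cc1F` differs from compound 2 by 1-hydroxyethyl in place of ethynyl on a saturated chain carbon bound to an oxygen on an unsaturated carbon. For the measured compounds named here, the only measured step bearing on this is a number 1.09 log units higher from compound 1 to compound 2 (beyond the scatter), a large one, with propargyloxy in place of amino on a double-bonded nitrogen. A smaller step towards a lower number is expected in this assay. The expected step is a number 0.59 log units lower from compound 2 to compound 3 (beyond the scatter). The estimate for compound 3 is 2.75, with an expected range of 2.35 to 3.15.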

Compound 3, partition coefficient: 2.75
Estimate against measurement, compound 3: no gap at the digits printed; the measured number falls inside the stated range.
By their numbers in this assay, from the lowest: compound 1; then compound 3; then compound 2.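

In this assay, 1-hydroxyethyl in place of ethynyl on a saturated chain carbon bound to an oxygen on an unsaturated carbon gives a number 0.59 log units lower from compound 2 to compound 3 (beyond the scatter), so the number shifts with a change at the far end of this chain, not only with replacing amino. With 2-hydroxypropoxy in place of amino on a double-bonded nitrogen there is still a number 0.50 log units higher from compound 1 to compound 3 (beyond the scatter), a modest step where propargyloxy gave a large one. Nothing available explains either step.

Open, from the compounds shown here alone, is how this assay reads with an amine or a carboxylic acid at this chain end. Going by these compounds, a longer chain carrying the same hydroxyl is equally open.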